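Removing a methyl from compound 2

A few compounds are considered here, and "the series" means these few. Any claim that something is new, unique, unknown or untested is made for them only; others in the source may bear on it.

In a functional assay on HaCaT cells (Homo sapiens) for antiproliferative activity, read by sulforhodamine B assay, with a stated time of 3 days (a lower number here means a stronger inhibitor, a higher number a weaker inhibitor), compound 1 (`COC(=O)c1cc(CCc2cc(OC)ccc2O)ccc1O`) gives 1100 nM while compound 2 (`COC(=O)c1cc(CCc2cc(O)ccc2OC)ccc1O`) gives 8700 nM and so stands highest of the two, beyond the scatter. Compound 3 (`COC(=O)c1cc(CCc2cc(O)ccc2O)ccc1O`) differs from compound 2 with hydrogen in place of methyl on an oxygen on an aromatic ring, methoxy to hydroxy (hydrogen in place of methyl on an oxygen on an aromatic ring). Going by the values given here, no measured step shows this change, so the expectation rests only on the high position of compound 2 (8700 nM). An estimated fall (a 4.4-fold lower number from compound 2 to compound 3 (0.64 log units; beyond the scatter)) towards a stronger inhibitor, beyond the scatter, is expected. Compound 3 is estimated at 2000 nM and expected to fall between 500 nM and 7000 nM.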

Compound 3, half-maximal inhibitory concentration: 21000 nM
For compound 3 the middle estimate is 11-fold (1.02 log units) below the measured one, outside the stated range (above it).
By their numbers in this assay, from the lowest: compound 1; then compound 2; then compound 3.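

In this assay, methoxy to hydroxy moves towards a weaker inhibitor, not a stronger one: the change gives a 2.4-fold higher number from compound 2 to compound 3 (0.38 log units; beyond the scatter), and at a different oxygen it gives a 19-fold higher number from compound 1 to compound 3 (1.28 log units; beyond the scatter). Both steps run the same way, so in these compounds the methyl on the oxygen goes with the lower number. Nothing available explains this direction. The compounds shown leave open whether a longer chain on that oxygen, such as ethoxy, would keep or lower the number, and how an amine in place of the hydroxy would read.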